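The source may hold more compounds than are shown below. What is called first, only, known or untested is meant among the compounds shown, and "the series" means these compounds.

Two members of the shared core have been measured so far. Compound 1 `Cc1nc2sc(-c3cccc(C(F)(F)F)c3)nc2c(=O)[nH]1` gives 15% in an assay on CHO cells for displacement of a labelled ligand from adenosine receptor A3 (Homo sapiens), read by scintillation counting, with a stated time of 120 min, tested at 1 uM; a higher number here means more inhibition at the concentration tested (going by the name of the read-out), a lower number less inhibition. Among the measured compounds shown here, compound 2 `Cc1nc2sc(Nc3ccccc3)nc2c(=O)[nH]1` gives 45% in this assay, the higher of the two numbers; its only neighbour is compound 1, and the gap between them lies beyond the usual scatter. For the measured compounds named here, no single-change pair between measured compounds is available, so the series gives no direct guide to the size of any step.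

The next compound, compound 3 `Cc1ccc(Nc2nc3c(=O)[nH]c(C)nc3s2)cc1`, differs from compound 2 in one place: methyl in place of hydrogen on an aromatic carbon. Going by the values given here, with no comparable step in hand, the expectation for this change in this assay is a modest one, most likely a small rise or none beyond the scatter rather than a large shift. The step expected is a number 5 percentage points higher from compound 2 to compound 3 (within the scatter). Compound 3 is estimated at 50%, with a range from 30% to 70%.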

Compound 3, a percentage reported as inhibition, at one concentration (the size of the read-out at that concentration, not a potency): 47%
For compound 3 the middle estimate is 3 percentage points above the measured one, within the range that was stated.
By their numbers in this assay, from the lowest: compound 1; then compounds 2 and 3 (each within the scatter of the next).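

Methyl in place of hydrogen on an aromatic carbon, para to a large group, gives a number 2 percentage points higher from compound 2 to compound 3 (within the scatter) in this assay. Among the compounds shown here, this is the first single-change pair, and it gives a first measure of step size on the shared core: at this position on the six-membered aromatic ring of carbon only, adding this one carbon leaves the reading within the scatter. No independent measurement bears on why this step is so small.

Going by these compounds, a single small group at a single position says little about the position in general, so whether a methoxy group, a chlorine atom or a longer chain such as propyl would give a step beyond the scatter remains open. On these data alone, the effect of methyl on the other aromatic carbons of this ring also remains open.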